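Adding Chloro to the Core of Compound 1

A few compounds are considered here, and "the series" means these few. Any claim that something is new, unique, unknown or untested is made for them only; others in the source may bear on it.

In a functional assay on MV4-11 cells (Homo sapiens) for antiproliferative activity, read by CellTiter-Glo, with a stated time of 72 h (a lower number here means a stronger inhibitor, a higher number a weaker inhibitor), compound 1 `CO[C@@H]1[C@H](N(C)c2ncc(-c3c[nH]c4ccc(F)cc34)s2)C[C@H]2O[C@]1(C)n1c3ccccc3c3c4c(c5c6ccccc6n2c5c31)C(=O)NC4` gives 510 nM, the highest of the three numbers shown, although all three lie within the scatter of one another. Compound 2 `CO[C@@H]1[C@H](N(C)c2ncc(-c3c[nH]c4ccc(Br)cc34)s2)C[C@H]2O[C@]1(C)n1c3ccccc3c3c4c(c5c6ccccc6n2c5c31)C(=O)NC4` gives 410 nM and compound 3 `COc1ccc2[nH]cc(-c3cnc(N(C)[C@@H]4C[C@H]5O[C@@](C)([C@@H]4OC)n4c6ccccc6c6c7c(c8c9ccccc9n5c8c64)C(=O)NC7)s3)c2c1` gives 360 nM in this assay. Compound 4 `CO[C@@H]1[C@H](N(C)c2ncc(-c3c[nH]c4ccc(F)cc34)s2)C[C@H]2O[C@]1(C)n1c3ccccc3c3c4c(c5c6cc(Cl)ccc6n2c5c31)C(=O)NC4` differs from compound 1 by chloro in place of hydrogen on an aromatic carbon. For the measured compounds named here, no measured step touches this part of the shared core; the steps of a 1.2-fold lower number from compound 1 to compound 2 (0.09 log units; within the scatter) and a 1.4-fold lower number from compound 1 to compound 3 (0.15 log units; within the scatter) exchange groups on a different aromatic carbon and both stayed within the scatter. On that basis compound 4 is expected to give a number close to that of compound 1, a step of a 1.0-fold lower number from compound 1 to compound 4 (0.01 log units; within the scatter) with no direction beyond the scatter. The estimate for compound 4 in this assay is 500 nM, between 180 nM and 1400 nM.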

Compound 4, half-maximal inhibitory concentration: 320 nM
Compound 4: middle estimate off by 1.6-fold (0.19 log units), on the high side; the range from low to high includes it.
By their numbers in this assay, from the lowest: compounds 4, 3, 2 and 1 (each within the scatter of the next).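

In this assay, chloro in place of hydrogen on an aromatic carbon of the shared core gives a 1.6-fold lower number from compound 1 to compound 4 (0.20 log units; within the scatter). For the compounds shown here, this is the first measured change at this position, and it shows that a chlorine atom can sit there without moving the number beyond the scatter. No measurement here offers an explanation for this step.

As far as these compounds go, whether an amine or a carboxylic acid at this position would also stay within the scatter remains open. So does whether chloro here would give a similar result alongside the bromo of compound 2 or the methoxy of compound 3.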